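The source may report more compounds than this note shows. Statements on the series, on what has been measured and on what is new or still open speak of the compounds shown alone.

- Compound 1 `CC(=O)N1CCC(c2ccc3c(c2)oc(=O)n3C(=O)NCCCCc2ccccc2)CC1`: 1 h
- Compound 2 `O=C(NCCCCc1ccccc1)n1c2c(oc1=O)CNCC2`: < 0.25 h, a limit

Among the compounds with values here, in an ADME assay on microsomes from liver (Mus musculus) for metabolic stability, read by LC-MS, using NADPH, with stated times of 15 min and 60 min, tested at 4.6 uM (a lower number here means that the compound disappears faster, a higher number that the compound lasts longer), compound 1 gives 1 h, the only exact number available. Compound 2 reports < 0.25 h, which is a limit of the assay. Compound 3 `CN1CCN(c2ccc3c(c2)oc(=O)n3C(=O)NCCCCc2ccccc2)C(=O)C1` has 4-methyl-2-oxopiperazin-1-yl in place of the 1-acetylpiperidin-4-yl of compound 1, on an aromatic carbon (4-methyl-2-oxopiperazin-1-yl in place of 1-acetylpiperidin-4-yl on an aromatic carbon). Within the data shown here, no measured pair shows this change, so no shift beyond the usual scatter is expected in this assay. The estimated change is a 1.4-fold lower number from compound 1 to compound 3 (0.15 log units; within the scatter). The estimated half-life of compound 3 is 0.7 h, with an expected range of 0.25 h to 2 h.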

Compound 3, half-life: < 0.0834 h
Compound 3: only a limit was reported (the forecaster's own chance of this, stated with the estimate: 20%); middle value at least 8.3-fold (0.92 log units) away from the limit.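

In this assay, within the data shown here, this position on the aromatic carbon turns out to be sensitive to the ring placed there: 4-methyl-2-oxopiperazin-1-yl in place of 1-acetylpiperidin-4-yl gives an at least 11-fold lower number from compound 1 to compound 3 (1.07 log units; beyond the scatter), the only step that can be read here. Compound 3 reports < 0.0834 h, which is a limit of the assay, so the full size of the step stays unfixed: the limit of < 0.0834 h in this assay, at which 1 of the 3 values shown sits.

Which part of the entering ring carries the step remains open. So does whether a morpholine or an open-chain amine on this carbon would stay closer to compound 1.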